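Swapping the sulfonyl aryl of compound 2 for a naphthalene

The compounds below may be only part of what the source reports. "The series", "measured", "known", "first", "only" and "open" are said of these compounds alone.

Of the compounds shown here, three sharing one core have been measured. Compound 1 `Cc1ccccc1C(=O)NCc1ccc(CNS(=O)(=O)c2ccccc2C)cc1` gives 10 nM in an assay on MDA-MB-231 cells for displacement of a labelled ligand from C-X-C chemokine receptor type 4 (Homo sapiens), read by fluorescence and microscopy, with stated times of 10 min and 30 min; a higher number here means that more compound is needed for the effect, a lower number that less compound is needed. Compound 2 `O=C(NCc1ccc(CNS(=O)(=O)c2cccc(F)c2)cc1)c1cccnc1` gives 1000 nM in this assay, and compound 3 `COc1ccccc1C(=O)NCc1ccc(CNS(=O)(=O)c2cccc(F)c2)cc1` gives 1000 nM. Compound 2 thus stands level with compound 3, the two together at the highest numbers of the set, while compound 1 sits a long way lower. Going by the values given here, the one measured step, no change at the digits printed from compound 2 to compound 3 (within the scatter), touches only the group on the carbonyl carbon and leaves the sulfonyl side untouched.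

Compound 4 `O=C(NCc1ccc(CNS(=O)(=O)c2cccc3ccccc23)cc1)c1cccnc1` has not yet been measured. It differs from compound 2 by naphthalen-1-yl in place of 3-fluorophenyl on a sulfonyl sulfur, a change on the sulfonyl sulfur. Among the compounds with values here, no measured step alters that position alone; compound 1, which carries a different group on the sulfur, also carries a different amide, so its value cannot be assigned to the sulfur change. The expectation for compound 4 is therefore a modest gain, with a wide range, giving an expected step of a 3.3-fold lower number from compound 2 to compound 4 (0.52 log units; beyond the scatter). Compound 4 is estimated at 300 nM, between 50 nM and 2000 nM.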

Compound 4, effective concentration (reported as EC, without a stated level of effect): 1000 nM
Compound 4: middle estimate off by 3.3-fold (0.52 log units), on the low side; measured number inside the range.
By their numbers in this assay, from the lowest: compound 1; then compounds 2, 3 and 4 (each within the scatter of the next).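

In this assay, going by these compounds alone, this is the first measured change made only at the sulfonyl sulfur, and the step reads no change at the digits printed from compound 2 to compound 4 (within the scatter). With pyridin-3-yl kept on the carbonyl carbon, replacing 3-fluorophenyl with naphthalen-1-yl removes the fluorine and adds a second six-membered aromatic ring, yet the two compounds cannot be told apart in this measurement. No measurement offered here accounts for this result.

On these data alone, compound 1 gives 10 nM in this assay, but how much of that value belongs to its sulfonyl side and how much to its amide side stays open. Also open, as far as these compounds go, is what an amine or a carboxylic acid on the aromatic ring at the sulfonyl sulfur, or a simple methyl directly on that sulfur, would do to the number.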